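Swapping methoxy for fluoro on a longer-chain triazole

A few compounds are considered here, and "the series" means these few. Any claim that something is new, unique, unknown or untested is made for them only; others in the source may bear on it.

Of the compounds shown here, three have been measured in an ADME assay on RD cells (Homo sapiens) for cytotoxicity, read by MTT assay, with a stated time of 3 days; a higher number here means that more compound is tolerated, a lower number that less compound is tolerated. Compound 1 `CC[C@@H](CCn1cncn1)c1ccc(F)cc1` gives 91.6 ug/mL, and compound 2 `CC[C@@H](CCn1cncn1)c1ccc(OC)cc1` gives 115 ug/mL. These two differ in one place: fluoro in place of methoxy on an aromatic carbon. That change gave a 1.3-fold lower number from compound 2 to compound 1 (0.10 log units; within the scatter). Compound 3 `CCCC[C@H](CCn1cncn1)c1ccc(OC)cc1` gives 28.3 ug/mL, the lowest number of the three; how its core differs from that of compound 2 is not broken down here. Compound 4 `CCCC[C@H](CCn1cncn1)c1ccc(F)cc1` carries the same change relative to compound 3: fluoro in place of methoxy on an aromatic carbon. Because the earlier step of a 1.3-fold lower number from compound 2 to compound 1 (0.10 log units; within the scatter) was small, compound 4 is expected to stay close to compound 3, with an estimated step of a 1.3-fold lower number from compound 3 to compound 4 (0.11 log units; within the scatter). The expected value for compound 4 in this assay is therefore 22 ug/mL, most likely between 10 ug/mL and 45 ug/mL.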

Compound 4, half-maximal cytotoxic concentration: 35.2 ug/mL
Compound 4: middle estimate off by 1.6-fold (0.20 log units), on the low side; the measured number falls inside the stated range.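

In this assay, fluoro in place of methoxy gave a 1.2-fold higher number from compound 3 to compound 4 (0.09 log units; within the scatter). Set side by side, the two steps do not differ, and the swap carried over from one core to the other with no readable effect on either: the same change on two cores in this assay, a 1.3-fold lower number (0.10 log units; within the scatter) from compound 2 to compound 1 and a 1.2-fold higher number (0.09 log units; within the scatter) from compound 3 to compound 4, 1.6-fold (0.19 log units) apart, within the scatter of two such steps. Among the compounds shown here, this rests on only two closely related cores in one assay, and it does not show that the swap would stay this small on other cores or in other assays.

Still open, going by these compounds, is how other groups in the same place, para to a large group, would read, such as an amine or a carboxylic acid. For the compounds shown here, also open is whether the swap would stay as small on a longer chain than the one in compound 3.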